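Shortening the chain of a thiourea-bearing pyridazinone analogue

The compounds below may be only part of what the source reports. "The series", "measured", "known", "first", "only" and "open" are said of these compounds alone.

Measured so far:
compound 1, `C/N=C(\S)NCCCCCn1nc(-c2ccccc2)ccc1=O`: 35.3 mg/kg
compound 2, `C/N=C(/NC#N)NCCCCCCn1nc(-c2ccccc2)ccc1=O`: > 100 mg/kg
compound 3, `C/N=C(/NC#N)NCCCCCn1nc(-c2ccccc2)ccc1=O`: 100 mg/kg

In a functional assay on the whole organism (stomach) with Rattus norvegicus as the target (on this read-out higher numbers stand for an effect only at larger amounts of compound and lower numbers for an effect already at smaller amounts), compound 1 gives 35.3 mg/kg, the lowest of the two numbers shown. Compound 3 gives 100 mg/kg. For compound 2 the assay reports only a limit, > 100 mg/kg, as recorded in the limit of > 100 mg/kg in this assay, at which 1 of the 3 values shown sits. The change from compound 1 to compound 4, `C/N=C(\S)NCCCn1nc(-c2ccccc2)ccc1=O`, is a group of 5 heavy atoms (2 carbon, 2 nitrogen, 1 sulfur; no ring) in place of a group of 7 heavy atoms (4 carbon, 2 nitrogen, 1 sulfur; no ring), on a saturated chain carbon, three bonds along the chain from an aromatic nitrogen. For the measured compounds named here, no measured step makes this change directly. The two steps starting at compound 1, an at least 2.8-fold higher number from compound 1 to compound 2 (0.45 log units; beyond the scatter) and a 2.8-fold higher number from compound 1 to compound 3 (0.45 log units; beyond the scatter), exchange the thiourea group for a cyanoguanidine and do not touch the chain. The step of a number no higher from compound 2 to compound 3 (the limit leaves the size open) does shorten the chain by one carbon, but its size is not readable. The effect of taking two carbons out of the chain in compound 4 is therefore open, and the closest guide is the unchanged thiourea end shared with compound 1. Compound 4 is expected to stay near compound 1, with a step of a 1.3-fold higher number from compound 1 to compound 4 (0.11 log units; within the scatter) that is not expected to go beyond the scatter. Compound 4 is thus estimated at 45 mg/kg, with a range from 15 mg/kg to 150 mg/kg.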

Compound 4, dose for half-maximal effect: > 100 mg/kg
Compound 4 ended at the assay's limit; the forecaster's own chance of this, stated with the estimate: 25%; middle value at least 2.2-fold (0.34 log units) away from the limit.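

With the thiourea end kept and only the chain changed, the group of 5 heavy atoms in place of the group of 7 heavy atoms gives a clear loss of effect, an at least 2.8-fold higher number from compound 1 to compound 4 (0.45 log units; beyond the scatter), so the thiourea end alone does not preserve the effect seen for compound 1 and the chain at this position matters in its own right. In this assay compound 4 gives > 100 mg/kg, which is a limit of the assay and not a number. This is the first readable step that changes the chain while leaving the end group alone, and it reaches the top of the measured range: the limit of > 100 mg/kg in this assay, at which 2 of the 4 values shown sit.

The compounds shown do not tell whether a longer chain carrying the thiourea end would give a lower number than compound 1, which gives 35.3 mg/kg, or whether the response to chain length changes smoothly or abruptly. They also leave open how a urea or a simple amine at the chain end would behave with either chain, and the true size of the loss in compound 4 cannot be read.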